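Cytotoxicity limits across one ether series and a new analogue

The source may hold more compounds than are shown below. What is called first, only, known or untested is meant among the compounds shown, and "the series" means these compounds.

Three compounds share a core and differ only in the group carried on the oxygen. Compound 1 `CC1(Cc2ccccc2)OS(=O)(=O)C=C1OCc1ccccc1` is one of them. In an ADME assay on HEL cells (Homo sapiens) for cytotoxicity, with a stated time of 3 days (on this read-out lower numbers stand for higher toxicity in this test and higher numbers for lower toxicity in this test), compound 1 gives > 400000 nM, a limit of the assay rather than a number. Compound 2 `CCC1(Cc2ccccc2)OS(=O)(=O)C=C1OCC#N` is the second. In this assay compound 2 gives > 400000 nM, again a limit. Compound 3 `CCC1(Cc2ccccc2)OS(=O)(=O)C=C1OCc1ccccc1Cl` is the third. In this assay compound 3 gives >= 20000 nM, also a limit. The step that the two limits leave unreadable from compound 2 to compound 3 cannot be read, because the limit of > 400000 nM in this assay, at which 2 of the 3 values shown sit, and the limit of >= 20000 nM in this assay, at which 1 of the 3 values shown sits, leave no number between them. Compound 3 therefore stands only at a limit, and the two other values shown are limits as well.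

Compound 4 `CCC1(Cc2ccccc2)OS(=O)(=O)C=C1OCC=C(C)C` differs from compound 3 by 2-methylprop-1-en-1-yl in place of 2-chlorophenyl on a saturated chain carbon bound to an oxygen on an unsaturated carbon. Going by the values given here, no measured step bears readably on this change, since every value shown is a limit, and no size of step can be inferred from them. Compound 4 is therefore expected to show no cytotoxicity below the reported limits, with an estimate of 200000 nM spanning 20000 nM to 400000 nM. The expected step is a step that the limit leaves unreadable from compound 3 to compound 4, most likely returned only as a limit.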

Compound 4, minimum cytotoxic concentration: 400000 nM
For compound 4 the middle estimate is 2.0-fold (0.30 log units) below the measured one, within the range that was stated.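

With compound 4, the series gains its first plain number in this assay rather than a limit, and the data show a number no higher from compound 2 to compound 4 (the limit leaves the size open), so a group with no ring, 3-methylbut-2-en-1-yl, can be placed on this read-out at this oxygen, where compound 3 with its 2-chlorobenzyl cannot. Compound 3 remains a limit at >= 20000 nM. The step from compound 3 to compound 4 cannot be read, so the change from 2-chlorophenyl to 2-methylprop-1-en-1-yl has no measurable size, because the value at the other end of this step is a limit: the limit of >= 20000 nM in this assay, at which 1 of the 4 values shown sits.

The compounds shown leave open whether any group on this oxygen gives a clearly lower number in this assay, as every value so far is either a limit or the single number of compound 4. They also leave open how a chain ending in an amine or a carboxylic acid, or a longer chain than 3-methylbut-2-en-1-yl, would read at the same place.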